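Methoxy on a phenyl ring of a dihydropyridine ester

A few compounds are considered here, and "the series" means these few. Any claim that something is new, unique, unknown or untested is made for them only; others in the source may bear on it.

Compound 1 `COC(=O)C1=C(C)N(c2ccccc2)C=CC1c1ccccc1` was measured in a functional assay for inhibition, using microsomes, tested at 200 ug/mL (a lower number here means a stronger effect, a higher number a weaker effect of the compound at the concentration tested), where compound 1 gives -37.3%. Compound 3 `COC(=O)C1=C(C)N(c2ccccc2)C=C(C)C1c1ccccc1` shares most of its structure; the two cores differ by hydrogen in place of methyl on a double-bonded ring carbon, and in this assay compound 3 gives -37.4%, so that a number 0.1 percentage points lower from compound 1 to compound 3 (within the scatter). Compound 2 `COC(=O)C1=C(C)N(c2ccc(OC)cc2)C=C(C)C1c1ccccc1` carries the change (methoxy in place of hydrogen on an aromatic carbon), and in this assay compound 2 gives -28.9%. For the measured compounds named here, the measured step is a number 8.5 percentage points higher from compound 3 to compound 2 (within the scatter), the one precedent for a methoxy entering in this way. Compound 4 `COC(=O)C1=C(C)N(c2ccccc2)C=CC1c1ccc(OC)cc1` has not yet been measured. It differs from compound 1 by methoxy in place of hydrogen on an aromatic carbon, the same change as that from compound 3 to compound 2, and among these compounds the change occurs twice in all. The step expected in this assay is a number 8.3 percentage points higher from compound 1 to compound 4 (within the scatter), placed beside the earlier one, and it rests on a number 8.5 percentage points higher from compound 3 to compound 2 (within the scatter) alone. Compound 4 is therefore estimated to give -29% in this assay, with an expected range from -41% to -17%.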

Compound 4, a percentage reported as activity, at one concentration (the size of the read-out at that concentration, not a potency): -30.3%
Compound 4: middle estimate off by 1.3 percentage points, on the high side; the measured number falls inside the stated range.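

In this assay, methoxy in place of hydrogen gives a number 7 percentage points higher from compound 1 to compound 4 (within the scatter). Set beside the one earlier case, the step carries from one core to the other with no difference that can be told apart: the same change on two cores in this assay, a number 8.5 percentage points higher (within the scatter) from compound 3 to compound 2 and a number 7 percentage points higher (within the scatter) from compound 1 to compound 4, 1.5 percentage points apart, within the scatter of two such steps. For the compounds shown here, this is agreement between only two pairs, and since each step lies within the scatter, it does not show that the methoxy changes the read-out on either core, nor that a larger step would carry over in the same way; the phenyl that bears the methoxy is also not the same one in compound 2 and compound 4, so the comparison does not separate core from ring.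

The compounds shown leave open whether a group other than methoxy on these phenyl rings, such as a hydroxyl, an ethoxy, a chlorine or an amine, would give a step beyond the scatter. They also leave open whether any such step would carry from one core to the other.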